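Cyclohexyl ester versus mesylate: Vero cytotoxicity notes

A few compounds are considered here, and "the series" means these few. Any claim that something is new, unique, unknown or untested is made for them only; others in the source may bear on it.

Compound 1 `Cc1cccc(C(=O)OC2CCC(CN3CCN(c4cc(=O)c5cc(C(F)(F)F)cc([N+](=O)[O-])c5s4)CC3)CC2)c1` carries a (3-methylphenyl)carbonyl ester on the cyclohexyl oxygen; in an ADME assay on Vero cells (Chlorocebus sabaeus) for cytotoxicity, read by MTT assay, with a stated time of 48 h (on this read-out higher numbers stand for weaker inhibition and lower numbers for stronger inhibition), compound 1 gives only a limit, > 64 ug/mL. Compound 2 `CS(=O)(=O)OC1CCC(CN2CCN(c3cc(=O)c4cc(C(F)(F)F)cc([N+](=O)[O-])c4s3)CC2)CC1` carries methylsulfonyl on that oxygen; in this assay compound 2 also stands at a limit, > 64 ug/mL. The step that the two limits leave unreadable from compound 1 to compound 2 is therefore unreadable. Compound 3 `O=C(OC1CCC(CN2CCN(c3cc(=O)c4cc(C(F)(F)F)cc([N+](=O)[O-])c4s3)CC2)CC1)c1ccc(F)cc1` differs from compound 2 by (4-fluorophenyl)carbonyl in place of methylsulfonyl on an oxygen on a saturated carbon. Within the data shown here, no measured step bears on this change; compound 1, the other aryl ester, gives no inhibition below the limit because the limit of > 64 ug/mL in this assay, at which 2 of the 2 values shown sit, holds both values. For compound 3 the expected step is a step that the limit leaves unreadable from compound 2 to compound 3, none beyond the scatter. Compound 3 is expected to give 80 ug/mL, between 40 ug/mL and 160 ug/mL, most probably again only a limit.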

Compound 3, half-maximal inhibitory concentration: > 64 ug/mL
Compound 3 ended at the assay's limit (the forecaster's own chance of this, stated with the estimate: 85%); the middle value does not contradict the limit.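

No step can be read among compound 1, compound 2 and compound 3, because all three stand only at a limit: the limit of > 64 ug/mL in this assay, at which 3 of the 3 values shown sit. In this assay the compounds shown leave open whether methylsulfonyl, (3-methylphenyl)carbonyl and (4-fluorophenyl)carbonyl on that oxygen differ at all.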